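This account rests on a few compounds, and the source may have more. Where it says the series, first, only, none or still open, it means among the compounds named here.

Working notes on the series.

Compound 1, `O=C(Nc1cccc(Cl)c1)Nc1cccc(CNc2ncnc3ccccc23)c1`, in a functional assay on HepG2 cells (Homo sapiens) for antiproliferative activity, read by MTT assay (on this read-out higher numbers stand for weaker inhibition and lower numbers for stronger inhibition), gives only a limit, > 50000 nM. Going by the values given here, compound 2, `COc1cc2ncnc(NCc3cccc(NC(=O)Nc4ccccc4)c3)c2cc1OC`, gives in this assay the single numerical value of the set, 19700 nM. The other entry, that of compound 1, is a limit: the limit of > 50000 nM in this assay, at which 1 of the 2 values shown sits. Compound 3, `COc1cc2ncnc(NCc3cccc(NC(=O)Nc4ccccc4F)c3)c2cc1OC`, differs from compound 2 by fluoro in place of hydrogen on an aromatic carbon. Among the compounds with values here, no measured step covers this change, so no step beyond the usual scatter is expected in this assay, in either direction. For compound 3 the expected step from this change is a 1.2-fold lower number from compound 2 to compound 3 (0.09 log units; within the scatter). Compound 3 is estimated in this assay at 16000 nM, with a range from 6000 nM to 45000 nM.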

Compound 3, half-maximal inhibitory concentration: 24900 nM
Beside the measured number, compound 3's estimate is 1.6-fold (0.19 log units) below it; the measured number falls inside the stated range.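

In this assay, fluoro in place of hydrogen on an aromatic carbon, ortho to a large group, gives a 1.3-fold higher number from compound 2 to compound 3 (0.10 log units; within the scatter). Going by these compounds alone, this is the first measured step at this place on the phenyl ring, and it shows that phenyl to 2-fluorophenyl leaves the number within the scatter. Nothing measured here bears on the size of this step. From the compounds shown here alone, whether methoxy, an amine or a carboxylic acid at this carbon would move the number beyond the scatter stays open. So does the effect of fluoro on the other carbons of this ring.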